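The compounds below may be only part of what the source reports. "The series", "measured", "known", "first", "only" and "open" are said of these compounds alone.

Of the compounds shown here, three sharing one core have been measured in a functional assay on HepG2 cells (Homo sapiens) for antiproliferative activity, read by CCK-8 assay, with a stated time of 72 h; a higher number here means a weaker inhibitor, a lower number a stronger inhibitor. Compound 1 `Cc1ccccc1C(=O)Nc1cccc(-c2oc3cc(-c4ccc(F)cc4)ccc3c(=O)c2O)c1` gives 19400 nM, compound 2 `COc1cccc(C(=O)Nc2cccc(-c3oc4cc(-c5ccc(F)cc5)ccc4c(=O)c3O)c2)c1` gives 9950 nM, and compound 3 `Cc1cccc(C(=O)Nc2cccc(-c3oc4cc(-c5ccc(F)cc5)ccc4c(=O)c3O)c2)c1` gives 13500 nM. Compound 2 has the lowest of the three numbers, but its nearest neighbour on that scale is compound 3, and the step of a 1.4-fold higher number from compound 2 to compound 3 (0.13 log units; within the scatter) lies within the scatter, as does the step of a 1.9-fold lower number from compound 1 to compound 2 (0.29 log units; within the scatter). So far, swapping one substituted phenyl ring on the carbonyl carbon for another has not moved the number beyond what repeated measurement would show.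

Compound 4 `O=C(Nc1cccc(-c2oc3cc(-c4ccc(F)cc4)ccc3c(=O)c2O)c1)c1cc(F)cc(F)c1` is not yet measured. It differs from compound 2 in this way: 3,5-difluorophenyl in place of 3-methoxyphenyl on a carbonyl carbon. Within the data shown here, the steps that bear on this are the two already named, both within the scatter, and both involving a change on the same phenyl ring attached to the carbonyl carbon. Among the measured compounds shown here, no measured step shows a change of this size in either direction beyond the scatter, so the expectation for compound 4 is a number close to that of compound 2, with the step of a 1.2-fold higher number from compound 2 to compound 4 (0.08 log units; within the scatter) expected to fall within the usual spread. Compound 4 is therefore estimated at 12000 nM, with a range from 5000 nM to 30000 nM.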

Compound 4, half-maximal inhibitory concentration: 4960 nM
Compound 4: the middle estimate sits 2.4-fold (0.38 log units) above what was measured; the measured number lies below the stated range.
By their numbers in this assay, from the lowest: compounds 4, 2, 3 and 1 (each within the scatter of the next, the first and the last beyond it).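

In this assay, among these compounds, the 3,5-difluorophenyl group on the carbonyl carbon gives the first steps at this position that clear the scatter: a 2.7-fold lower number from compound 3 to compound 4 (0.43 log units; beyond the scatter) and a 3.9-fold lower number from compound 1 to compound 4 (0.59 log units; beyond the scatter), both modest in size. Against the 3-methoxyphenyl group the same ring does not clear it, with a 2.0-fold lower number from compound 2 to compound 4 (0.30 log units; within the scatter), so these two groups cannot be told apart here, and the position shows only a small response to the change so far. Nothing available here explains these steps.

As far as these compounds go, all four compounds carry a substituted phenyl ring at this position, so it remains open how an amine, a carboxylic acid or a longer chain would behave in its place. Also open, from the compounds shown here alone, is whether a phenyl ring with a single fluorine would give a number like that of compound 4.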